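The source may hold more compounds than are shown below. What is called first, only, known or untested is meant among the compounds shown, and "the series" means these compounds.

Compound 1 `CCC1CCN(c2cc(C(F)(F)F)ccc2CNC(=O)C(C)c2ccc(NS(C)(=O)=O)c(F)c2)CC1` gives 0.7 nM in an assay on CHO cells for antagonist activity at transient receptor potential cation channel subfamily V member 1 (Homo sapiens), read by FLIPR; a higher number here means a weaker inhibitor, a lower number a stronger inhibitor.
Compound 2 `CC(C(=O)NCc1ccc(C(F)(F)F)cc1N1CCC(C(F)(F)F)CC1)c1ccc(NS(C)(=O)=O)c(F)c1` gives 0.4 nM.
Compound 3 `C[C@H](C(=O)NCc1ccc(C(F)(F)F)cc1SC1CCCCC1)c1ccc(NS(C)(=O)=O)c(F)c1` gives 0.3 nM.

Compound 1 has the highest of the three numbers: compound 2 sits within the scatter of it, compound 3 beyond it. Compound 4 `CC(C(=O)NCc1ccc(C(F)(F)F)cc1SCc1ccccc1)c1ccc(NS(C)(=O)=O)c(F)c1` differs from compound 1 in one place: benzylsulfanyl in place of 4-ethylpiperidin-1-yl on an aromatic carbon. For the measured compounds named here, no measured step covers this exchange. Going by the values given here, the only measured step, a 1.8-fold lower number from compound 1 to compound 2 (0.24 log units; within the scatter), touches a different part of the saturated ring and stays within the scatter. Compound 3, which also carries a sulfanyl group in that place, gives 0.3 nM, so such a group can sit there without loss. A step of at most modest size is therefore expected, in either direction. For compound 4 the estimate is 0.6 nM, between 0.2 nM and 2 nM. The expected step is a 1.2-fold lower number from compound 1 to compound 4 (0.07 log units; within the scatter).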

Compound 4, inhibition constant: 0.5 nM
Compound 4: the middle estimate sits 1.2-fold (0.08 log units) above what was measured; measured number inside the range.
By their numbers in this assay, from the lowest: compounds 3, 2, 4 and 1 (each within the scatter of the next, the first and the last beyond it).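

At this aromatic carbon, benzylsulfanyl replaces a piperidine ring joined through nitrogen with no change beyond the scatter in this assay (a 1.4-fold lower number from compound 1 to compound 4 (0.15 log units; within the scatter)) (a 1.3-fold higher number from compound 2 to compound 4 (0.10 log units; within the scatter)). The position therefore accepts an aromatic ring joined through a sulfur-containing link as well as the saturated rings of compound 1 and compound 2, even though the atom attached to the aromatic carbon and the ring type both differ. No supporting measurement explains this tolerance. As far as these compounds go, whether benzyloxy, with oxygen in place of sulfur, or a group carrying a carboxylic acid would fit here remains open.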